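From Methyl to Dimethylamino: Estimating Compound 4

The compounds below may be only part of what the source reports. "The series", "measured", "known", "first", "only" and "open" are said of these compounds alone.

Measured in an assay on isolated protein for displacement of a labelled ligand from acyl-CoA:cholesterol acyltransferase (Oryctolagus cuniculus); a higher number here means a weaker inhibitor, a lower number a stronger inhibitor:
compound 1 `CC(C)c1cccc(C(C)C)c1NC(=O)Nc1nc2ccccc2n1-c1ccc(Cl)cc1`, 280 nM
compound 2 `CC(C)c1cccc(C(C)C)c1NC(=O)Nc1nc2ccccc2n1-c1ccccc1Br`, 22 nM
compound 3 `Cc1ccccc1-n1c(NC(=O)Nc2c(C(C)C)cccc2C(C)C)nc2ccccc21`, 19 nM

Compound 3 has the lowest of the three numbers; compound 2 sits within the scatter of it, while compound 1 lies far above it. Compound 4 `CC(C)c1cccc(C(C)C)c1NC(=O)Nc1nc2ccccc2n1-c1ccccc1N(C)C` differs from compound 3 by dimethylamino in place of methyl on an aromatic carbon. Within the data shown here, the steps that bear on this change are a 13-fold lower number from compound 1 to compound 2 (1.10 log units; beyond the scatter) and a 15-fold lower number from compound 1 to compound 3 (1.17 log units; beyond the scatter), both large, and a 1.2-fold lower number from compound 2 to compound 3 (0.06 log units; within the scatter), within the scatter; exchanging one small group for another at this position thus left the number unchanged, while moving the group changed it greatly. On that basis the step of a 1.6-fold higher number from compound 3 to compound 4 (0.20 log units; within the scatter) is expected to stay within the scatter, and compound 4 is estimated at 30 nM, between 10 nM and 100 nM.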

Compound 4, half-maximal inhibitory concentration: 41 nM
Compound 4: the middle estimate sits 1.4-fold (0.14 log units) below what was measured; the range from low to high includes it.
By their numbers in this assay, from the lowest: compounds 3, 2 and 4 (each within the scatter of the next, the first and the last beyond it); then compound 1.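

In this assay, among these compounds, dimethylamino, with its three heavy atoms and one hydrogen-bond acceptor, is the first exchange at this place on the ring to go beyond the scatter, with a 2.2-fold higher number from compound 3 to compound 4 (0.33 log units; beyond the scatter) against methyl, although a 1.9-fold higher number from compound 2 to compound 4 (0.27 log units; within the scatter) against bromo stays within it. The 2-(dimethylamino)phenyl group still keeps much of the distance from the 4-chlorophenyl compound, with a 6.8-fold lower number from compound 1 to compound 4 (0.83 log units; beyond the scatter) remaining between them. Nothing shown here explains these steps.

From the compounds shown here alone, how an ethyl group, a methoxy group or a primary amine would compare at this place remains open. So does whether the step follows the nitrogen or the added carbons.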